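A Bromophenyl Swap at the Sulfur

The compounds below may be only part of what the source reports. "The series", "measured", "known", "first", "only" and "open" are said of these compounds alone.

In a functional assay on SGC-7901 cells (Homo sapiens) for cytotoxicity, read by MTT assay, with a stated time of 48 h (a higher number here means a weaker inhibitor, a lower number a stronger inhibitor), compound 1 (`O=C(CSc1ccc([N+](=O)[O-])cc1)N1N=C(c2cc3ccccc3oc2=O)C[C@@H]1c1ccccc1C(F)(F)F`) gives 9770 nM and compound 2 (`O=C(CSCc1ccco1)N1N=C(c2cc3ccccc3oc2=O)C[C@@H]1c1ccccc1C(F)(F)F`) gives 10300 nM on the same read-out, so compound 2 stands level with compound 1. For the measured compounds named here, the one measured step between them is a 1.1-fold higher number from compound 1 to compound 2 (0.02 log units; within the scatter) and puts (furan-2-yl)methyl in place of 4-nitrophenyl on a sulfur. Compound 3 (`O=C(CSc1ccc(Br)cc1)N1N=C(c2cc3ccccc3oc2=O)C[C@@H]1c1ccccc1C(F)(F)F`) differs from compound 2 at that same sulfur, with 4-bromophenyl in place of (furan-2-yl)methyl on a sulfur as the counted change, so 4-bromophenyl stands where compound 1 has 4-nitrophenyl. Going by the values given here, no measured compound yet carries bromine. Among the compounds with values here, with a 1.1-fold higher number from compound 1 to compound 2 (0.02 log units; within the scatter) as the only guide, no shift beyond the scatter is expected in this assay for this change. The expected change is a 1.1-fold lower number from compound 2 to compound 3 (0.04 log units; within the scatter) in size. Compound 3 is estimated at 9500 nM with an expected range from 4000 nM to 22000 nM in this measurement.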

Compound 3, half-maximal inhibitory concentration: 14700 nM
Compound 3: middle estimate off by 1.5-fold (0.19 log units), on the low side, within the range that was stated.
By their numbers in this assay, from the lowest: compounds 1, 2 and 3 (each within the scatter of the next).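

In this assay, this sulfur now holds a third group and the number still does not move beyond the scatter: 4-bromophenyl in place of (furan-2-yl)methyl gives (a 1.4-fold higher number from compound 2 to compound 3 (0.15 log units; within the scatter)), and bromo in place of nitro on an aromatic carbon gives (a 1.5-fold higher number from compound 1 to compound 3 (0.18 log units; within the scatter)). The second step is new in kind, as it keeps the aromatic ring on the sulfur and exchanges only the group it carries, and it too stays within the scatter. No measurement at hand bears on why these groups read alike.

On these data alone, all three compounds carry an aromatic ring in this group, so it remains open whether an amine, a carboxylic acid or a longer saturated chain on the sulfur would shift the number beyond the scatter. As far as these compounds go, it is also open whether this flat picture would hold with the trifluoromethyl group of the shared core replaced.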